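Chloro to bromo on the piperidin-1-yl compound

The source may report more compounds than this note shows. Statements on the series, on what has been measured and on what is new or still open speak of the compounds shown alone.

Among the measured compounds shown here, in a functional assay on Hs 683 cells (Homo sapiens) for cytotoxicity, read by MTT assay, with a stated time of 72 h (on this read-out lower numbers stand for stronger inhibition and higher numbers for weaker inhibition), compound 3 `O=C(c1ccccc1)c1sc(N2CCCCC2)nc1Cl` gives 36000 nM, the only actual number in this small series.

Compound 1 `CSc1nc(Br)c(C(=O)c2ccccc2)s1` reads > 100000 nM, which is a limit and not a number.

Compound 2 `O=C(c1ccccc1)c1sc(N2CCCC2)nc1Br` reads > 100000 nM, again a limit.

The remaining values are thus bounded by the limit of > 100000 nM in this assay, at which 2 of the 3 values shown sit.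

Compound 4 `O=C(c1ccccc1)c1sc(N2CCCCC2)nc1Br` is related to compound 3 by bromo in place of chloro on an aromatic carbon.

For the measured compounds named here, the only measured step is a step that the two limits leave unreadable from compound 1 to compound 2. It concerns a different place and offers no usable size, so no shift beyond the scatter is expected in this assay.

The expected change is a 1.1-fold higher number from compound 3 to compound 4 (0.05 log units; within the scatter).

Compound 4 is estimated at 40000 nM, with an expected range of 17000 nM to 95000 nM.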

Compound 4, half-maximal inhibitory concentration: 38000 nM
For compound 4 the middle estimate is 1.1-fold (0.02 log units) above the measured one; the measured number falls inside the stated range.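

Bromo in place of chloro, on the aromatic carbon next to the ring nitrogen, gives a 1.1-fold higher number from compound 3 to compound 4 (0.02 log units; within the scatter) in this assay, so this position shows no response to this halogen change. With bromo held, piperidin-1-yl in place of pyrrolidin-1-yl gives an at least 2.6-fold lower number from compound 2 to compound 4 (0.42 log units; beyond the scatter), and piperidin-1-yl in place of methylsulfanyl gives an at least 2.6-fold lower number from compound 1 to compound 4 (0.42 log units; beyond the scatter). Both sizes are bounds only, because compounds 1 and 2 rest on a limit: the limit of > 100000 nM in this assay, at which 2 of the 4 values shown sit.

Still open, on these data alone, is whether a methyl group or a nitrile at the halogen position would shift the number. Also open, as far as these compounds go, is how morpholin-4-yl would compare with piperidin-1-yl.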